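The source may hold more compounds than are shown below. What is called first, only, known or untested is meant among the compounds shown, and "the series" means these compounds.

Measured so far: compound 1 `CCC1(CCCCN2CCN(c3ccc(Cl)cc3)CC2)C(=O)Nc2cc(F)c(Cl)cc21` and compound 2 `CCC1(CCCCN2CC=C(c3ccc(F)cc3)CC2)C(=O)Nc2ccccc21`.

In an assay on CHO cells for displacement of a labelled ligand from 5-hydroxytryptamine receptor 7 (Homo sapiens) (on this read-out higher numbers stand for weaker inhibition and lower numbers for stronger inhibition), compound 1 gives 6.99 nM. In this assay compound 2 gives 1.19 nM. Compound 1 thus stands at the higher of the two numbers, and the gap to compound 2 lies beyond the usual scatter; the two compounds differ in more than one place, so the gap is not tied to any single change.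

The next compound, compound 3 `CCC1(CCCCN2CCN(c3cccc(Cl)c3)CC2)C(=O)Nc2cc(F)c(Cl)cc21`, is the one-point variant of compound 1: 3-chlorophenyl in place of 4-chlorophenyl on an amine nitrogen in a ring. Going by the values given here, no pair among the measured compounds isolates this change, so no measured step can be carried over. A shift of the chlorine around the aryl ring is expected to move the number only a little, most likely within the scatter or toward a slightly weaker result. The step from compound 1 to compound 3 is expected to be a 1.4-fold higher number from compound 1 to compound 3 (0.16 log units; within the scatter). For compound 3 the estimate in this assay is 10 nM, with a range from 3.5 nM to 30 nM.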

Compound 3, inhibition constant: 9.07 nM
For compound 3 the middle estimate is 1.1-fold (0.04 log units) above the measured one; low and high end bracket the measured number.
By their numbers in this assay, from the lowest: compound 2; then compounds 1 and 3 (each within the scatter of the next).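

Going by these compounds alone, this is the first pair that isolates a single change: 3-chlorophenyl in place of 4-chlorophenyl on an amine nitrogen in a ring, with the core of compound 1 left as it is. In this assay the exchange gives a 1.3-fold higher number from compound 1 to compound 3 (0.11 log units; within the scatter), so with this core the read-out does not separate the two chlorine placements on the aryl ring. Nothing at hand offers an explanation for this outcome.

The compounds shown leave open how this assay responds when the aryl group on this nitrogen carries something other than a single halogen, such as a methoxy group or a nitrile. Also open, from the compounds shown here alone, is whether the same chlorine exchange would read alike on the scaffold of compound 2.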